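Sulfonamide Inhibitors of Tissue-Nonspecific Alkaline Phosphatase: Amide Variation

This account rests on a few compounds, and the source may have more. Where it says the series, first, only, none or still open, it means among the compounds named here.

Measured compounds in an assay on isolated protein for inhibition of alkaline phosphatase, tissue-nonspecific isozyme (Homo sapiens); a lower number here means a stronger inhibitor, a higher number a weaker inhibitor:
Compound 1, `COc1ccc(Cl)cc1S(=O)(=O)Nc1cncc(C(=O)Nc2ccccc2)c1`, gives 310 nM.
Compound 2, `COc1ccc(C(F)(F)F)cc1S(=O)(=O)Nc1cccnc1`, gives 183 nM.
Compound 3, `COc1ccc(C(F)(F)F)cc1S(=O)(=O)Nc1cnc2ccccc2c1`, gives 26 nM.

Among these three, compound 1 has the highest number in this assay. Compound 2 lies within the scatter of compound 1, so no order between the two can be drawn; compound 3 lies well beyond it, with a markedly lower number. Compound 4, `COc1ccc(Cl)cc1S(=O)(=O)Nc1cncc(C(=O)N2CCN(C)CC2)c1`, has not yet been measured. It differs from compound 1 in one place: 4-methylpiperazin-1-yl in place of anilino on a carbonyl carbon. For the measured compounds named here, no step between measured compounds tests this kind of change, so any expectation rests on compound 1 alone. The step is expected to be a modest weakening, a 2.3-fold higher number from compound 1 to compound 4 (0.35 log units; beyond the scatter), near the edge of the scatter. Compound 4 is therefore estimated at 700 nM, within a range from 250 nM to 2500 nM.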

Compound 4, half-maximal inhibitory concentration: 671 nM
Estimate against measurement, compound 4: 1.0-fold (0.02 log units) above, within the range that was stated.
By their numbers in this assay, from the lowest: compound 3; then compounds 2 and 1 (each within the scatter of the next); then compound 4.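

For the compounds shown here, the first reading at this position in this assay is a 2.2-fold higher number from compound 1 to compound 4 (0.34 log units; beyond the scatter), a modest step for 4-methylpiperazin-1-yl in place of anilino on the carbonyl carbon. The change removes both the aromatic ring and the amide hydrogen, yet compound 4 remains measurable in the same nanomolar range as compound 1. No measured property available here accounts for the step.

Since the ring and the amide hydrogen leave together, the compounds shown cannot separate their contributions. Going by these compounds, whether a morpholin-4-yl or benzylamino group on the same carbonyl carbon would behave like anilino or like 4-methylpiperazin-1-yl remains open.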